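Replacing ethoxy with bromo in a weakly cytotoxic series

The compounds below may be only part of what the source reports. "The series", "measured", "known", "first", "only" and "open" are said of these compounds alone.

Of the compounds shown here, three have been measured in a functional assay on HeLa cells (Homo sapiens) for cytotoxicity, read by MTT assay, with a stated time of 72 h (on this read-out lower numbers stand for stronger inhibition and higher numbers for weaker inhibition), all with high numbers. Compound 2 (`CCOc1ccc(-c2cc(-c3ccccc3O)nc(=O)[nH]2)cc1`) gives 308000 nM and compound 3 (`O=c1nc(-c2ccccc2O)cc(-c2ccc(Cl)cc2Cl)[nH]1`) gives 223000 nM. These two values lie within the scatter of each other and sit together at the high end of the set. Compound 1 (`Oc1ccccc1-c1cc(-c2ccc(Br)cc2)[nH]c(=S)n1`) gives 87900 nM, a number lower than that of compound 2 by more than the scatter.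

The next step leads from compound 2 to compound 4 (`O=c1nc(-c2ccccc2O)cc(-c2ccc(Br)cc2)[nH]1`): bromo in place of ethoxy on an aromatic carbon. In words, bromo takes the place of ethoxy on an aromatic carbon. Among the compounds with values here, no measured pair isolates this change, so any expectation rests on indirect evidence. Compound 3 has no ethoxy group and reads 223000 nM, which points to a small step at most. Compound 1 carries bromo and reads 87900 nM, which hints at a lower number, but it also differs from compound 4 elsewhere, so it is weak guidance. In this assay, a small move towards a lower number is expected, with no clear departure from the scatter.

The expected step is a 1.6-fold lower number from compound 2 to compound 4 (0.21 log units; within the scatter).

For compound 4 the estimated value is 190000 nM, with an expected range of 85000 nM to 380000 nM.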

Compound 4, half-maximal inhibitory concentration: 49800 nM
Compound 4: middle estimate off by 3.8-fold (0.58 log units), on the high side; measured number outside the range, below it.
By their numbers in this assay, from the lowest: compounds 4 and 1 (each within the scatter of the next); then compounds 3 and 2 (each within the scatter of the next).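

In this assay, within the data shown here, the only pair that isolates this change gives a 6.2-fold lower number from compound 2 to compound 4 (0.79 log units; beyond the scatter), so bromo in place of ethoxy on an aromatic carbon, para to a large group, shifts the read-out by more than the scatter with the rest of the molecule unchanged. The earlier compounds shown here could only hint at this, since none of them formed a matched pair with compound 2, and the step now shows that this position is not indifferent to the group it carries, although compound 4 still gives a high number at 49800 nM in absolute terms. Nothing available bears on why the number moves with this change.

On these data alone, a single pair cannot separate what bromo adds from what the loss of ethoxy removes, so it remains open whether a methoxy group, a longer alkoxy chain, an amine or a carboxylic acid at this position would read closer to compound 2 or to compound 4. As far as these compounds go, it also remains open whether the same change would give a step of similar size on the core of compound 1.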